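This account rests on a few compounds, and the source may have more. Where it says the series, first, only, none or still open, it means among the compounds named here.

Working notes on a short series sharing the core of compound 1 `CCCc1cc(Cn2c(CC)nc3c(C)cc(C)nc32)cc(CCC)c1OC(C(=O)O)c1ccc(CC)cc1`. Among the compounds with values here, in an assay on isolated protein for displacement of a labelled ligand from Type-2 angiotensin II receptor (Rattus norvegicus) (a higher number here means a weaker inhibitor, a lower number a stronger inhibitor), compound 1 gives 240 nM, the lowest of the three numbers so far. Compound 2 `CCCc1cc(Cn2c(CC)nc3c(C)cc(C)nc32)cc(CCC)c1OC(C(=O)O)c1cccc(-c2ccccc2)c1` gives 740 nM in this assay, and compound 3 `CCCc1cc(Cn2c(CC)nc3c(C)cc(C)nc32)cc(CCC)c1OC(C(=O)O)c1ccc(Cl)cc1` gives 450 nM. The step of a 3.1-fold higher number from compound 1 to compound 2 (0.49 log units; beyond the scatter) is beyond the scatter, while the step of a 1.9-fold higher number from compound 1 to compound 3 (0.27 log units; within the scatter) and the step of a 1.6-fold lower number from compound 2 to compound 3 (0.22 log units; within the scatter) lie within it.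

Compound 4 `CCCc1cc(Cn2c(CC)nc3c(C)cc(C)nc32)cc(CCC)c1OC(C(=O)O)c1ccccc1` has not yet been measured. It differs from compound 1 by hydrogen in place of ethyl on an aromatic carbon. The step that bears most directly is a 1.9-fold higher number from compound 1 to compound 3 (0.27 log units; within the scatter), which also takes away the ethyl and stays within the scatter; the larger change a 3.1-fold higher number from compound 1 to compound 2 (0.49 log units; beyond the scatter) swaps the whole 4-ethylphenyl and goes beyond it. Taking the ethyl away with nothing in its place is expected to give a small upward move, a 1.6-fold higher number from compound 1 to compound 4 (0.20 log units; within the scatter), within or close to the scatter. Compound 4 is therefore estimated at 380 nM in this assay, with a range of 150 nM to 950 nM.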

Compound 4, half-maximal inhibitory concentration: 2600 nM
Estimate against measurement, compound 4: 6.8-fold (0.84 log units) below, outside the stated range (above it).
By their numbers in this assay, from the lowest: compounds 1, 3 and 2 (each within the scatter of the next, the first and the last beyond it); then compound 4.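

Taking the ethyl away from the position para to a large group costs far more than the earlier steps suggested (an 11-fold higher number from compound 1 to compound 4 (1.03 log units; beyond the scatter)), whereas chloro in place of ethyl stayed within the scatter. Within the data shown here, the unsubstituted ring also stands apart from the other two compounds (a 5.8-fold higher number from compound 3 to compound 4 (0.76 log units; beyond the scatter); a 3.5-fold higher number from compound 2 to compound 4 (0.55 log units; beyond the scatter)), so in this assay 4-ethylphenyl, 4-chlorophenyl and 3-phenylphenyl all give lower numbers than phenyl, and no compound here goes against this. Among these compounds, having a group on this ring counts for more than whether that group at the para position is ethyl or chloro.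

Still open, on these data alone, is how small a group can restore the lower number and whether methyl, fluoro, methoxy, an amine or a longer chain at this position would do so. No supporting data bear on why removing the ethyl has so large an effect.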